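Hydrazone aryl replacement: from compound 3 to compound 4

The source may report more compounds than this note shows. Statements on the series, on what has been measured and on what is new or still open speak of the compounds shown alone.

Measured compounds:
compound 1 `CN(C)CCn1cnnc1-c1cc(Oc2ccc(NC(=O)N/N=C/c3ccc(Cl)cc3)cc2F)ccn1` — 780 nM
compound 2 `COc1ccc(/C=N/NC(=O)Nc2ccc(Oc3ccnc(-c4nncn4CCN(C)C)c3)c(F)c2)c(OC)c1` — 2820 nM
compound 3 `COc1ccc(/C=N/NC(=O)Nc2ccc(Oc3ccnc(-c4nncn4CCN(C)C)c3)c(F)c2)cc1O` — > 100000 nM

In a functional assay on A549 cells (Homo sapiens) for cytotoxicity, read by MTT assay, with a stated time of 72 h (a lower number here means a stronger inhibitor, a higher number a weaker inhibitor), compound 1 gives 780 nM and compound 2 gives 2820 nM. For compound 3 the assay reports only a limit, > 100000 nM, and no number. Compound 3 sits at the limit of > 100000 nM in this assay, at which 1 of the 3 values shown sits, and is the weakest of the three shown, the steps of an at least 120-fold higher number from compound 1 to compound 3 (2.10 log units; beyond the scatter) and an at least 35-fold higher number from compound 2 to compound 3 (1.54 log units; beyond the scatter) both lying beyond the scatter.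

Compound 4 `CN(C)CCn1cnnc1-c1cc(Oc2ccc(NC(=O)N/N=C/c3ccc(Cl)cc3Cl)cc2F)ccn1` has not been measured. It differs from compound 3 in one place: 2,4-dichlorophenyl in place of 3-hydroxy-4-methoxyphenyl on a carbon with a double bond to nitrogen. Among the measured compounds shown here, the steps that bear on this are an at least 120-fold higher number from compound 1 to compound 3 (2.10 log units; beyond the scatter) and an at least 35-fold higher number from compound 2 to compound 3 (1.54 log units; beyond the scatter), both large losses when 3-hydroxy-4-methoxyphenyl entered. Compound 4 removes that group and returns to a chlorophenyl, so a large step downward is expected, an at least 100-fold lower number from compound 3 to compound 4 (2.00 log units; beyond the scatter). With compound 1 at 780 nM as the nearest chlorophenyl anchor, compound 4 is estimated at 1000 nM, within 300 nM to 6000 nM.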

Compound 4, half-maximal inhibitory concentration: 810 nM
The estimate for compound 4 lay 1.2-fold (0.09 log units) above the measured number; the measured number falls inside the stated range.
By their numbers in this assay, from the lowest: compounds 1 and 4 (each within the scatter of the next); then compound 2. At a limit, above all of these: compound 3.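

In this assay, a chloro in place of hydrogen on an aromatic carbon is tolerated on this aryl group: a 1.0-fold higher number from compound 1 to compound 4 (0.02 log units; within the scatter). With 2,4-dichlorophenyl in place of 2,4-dimethoxyphenyl the result is a 3.5-fold lower number from compound 2 to compound 4 (0.54 log units; beyond the scatter), so both chlorinated aryl groups now give lower numbers than the two methoxy-bearing aryl groups shown. With 2,4-dichlorophenyl in place of 3-hydroxy-4-methoxyphenyl the result is an at least 120-fold lower number from compound 3 to compound 4 (2.09 log units; beyond the scatter), and that step starts from a limit, not a number: the limit of > 100000 nM in this assay, at which 1 of the 4 values shown sits.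

Going by these compounds, whether the hydroxy group, the methoxy group or their combination in compound 3 carries the loss stays open. Also open, on these data alone, is how a phenyl with no substituent, a 4-fluorophenyl or a 4-hydroxyphenyl would stand on the carbon with a double bond to nitrogen.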